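Removing the Bromo Group from Compound 1

The compounds below may be only part of what the source reports. "The series", "measured", "known", "first", "only" and "open" are said of these compounds alone.

compound 1 `O=C(CCCCCCNC(=O)C(O)(O)C(F)(F)F)Nc1ncc(-c2ccc(Br)cc2)s1` with 2460 nM measured
compound 2 `O=C(CCCCCCNC(=O)C(O)(O)C(F)(F)F)Nc1nc2ccccc2o1` with 3450 nM measured

In a functional assay on HCT-116 cells (Homo sapiens) for inhibition, read by colorimetric assay, with a stated time of 3 days (on this read-out higher numbers stand for weaker inhibition and lower numbers for stronger inhibition), compound 1 gives 2460 nM and compound 2 gives 3450 nM as its own result. These two values lie within the usual scatter of each other, so neither compound stands apart from the other on these numbers. The step followed here leads to compound 3 `O=C(CCCCCCNC(=O)C(O)(O)C(F)(F)F)Nc1ncc(-c2ccccc2)s1` and puts hydrogen in place of bromo on an aromatic carbon so that 4-bromophenyl becomes phenyl, para to a large group, while the rest of the structure stays the same. For the measured compounds named here, no measured pair of compounds differs in only one place, so the data contain no direct measure of what this change does. The estimate therefore stays anchored on compound 1 at 2460 nM as its starting point. The expected step of a 1.2-fold higher number from compound 1 to compound 3 (0.09 log units; within the scatter) in this assay is a slight move towards weaker inhibition, and it is not expected to go beyond the scatter. For compound 3 the estimated value is 3000 nM with an expected range from 1200 nM to 7500 nM in this read-out.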

Compound 3, half-maximal inhibitory concentration: 2660 nM
Compound 3: middle estimate off by 1.1-fold (0.05 log units), on the high side; measured number inside the range.
By their numbers in this assay, from the lowest: compounds 1, 3 and 2 (each within the scatter of the next).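

For the compounds shown here, the step of a 1.1-fold higher number from compound 1 to compound 3 (0.03 log units; within the scatter) in this assay gives the first direct reading of this position, and it lies within the scatter. Compound 1 and compound 3 therefore cannot be told apart on these numbers: with the rest of the structure unchanged, the read-out does not depend on keeping the bromo group on this aromatic carbon, and plain phenyl does as well as 4-bromophenyl here. Nothing available here bears on why the change leaves the number within the scatter.

As far as these compounds go, only bromo and hydrogen are compared at this place, para to a large group, so it remains open whether an amine, a carboxylic acid or a methoxy group there would move the number beyond the scatter. Going by these compounds alone, it also remains open whether hydrogen in place of bromo would read the same in compounds with a longer chain than the one that compound 1 and compound 3 share.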